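Chloro on the Core of Compound 1: What to Expect

A few compounds are considered here, and "the series" means these few. Any claim that something is new, unique, unknown or untested is made for them only; others in the source may bear on it.

compound 1 `C[C@@H](Cn1ccc(-c2ccc(C#N)c(Cl)c2)n1)Nc1ncnc2nc[nH]c12`: 960 nM
compound 2 `C[C@H](Cn1ccc(-c2ccc(C#N)c(Cl)c2)n1)Nc1ncnc2nc[nH]c12`: 850 nM

In a functional assay on LNCaP cells (Homo sapiens) for antiproliferative activity, read by CCK-8 assay, with a stated time of 6 days (on this read-out lower numbers stand for stronger inhibition and higher numbers for weaker inhibition), compound 1 gives 960 nM, the higher of the two numbers, while compound 2 gives 850 nM. The step of a 1.1-fold lower number from compound 1 to compound 2 (0.05 log units; within the scatter) is within the scatter, which fits (the fact that compounds 1 and 2 differ only in the configuration as drawn). Compound 3 `C[C@@H](Cn1ccc(-c2ccc(C#N)c(Cl)c2)n1)Nc1nc(Cl)nc2nc[nH]c12` differs from compound 1 by chloro in place of hydrogen on an aromatic carbon. Within the data shown here, no measured step alters a substituent on the shared core, so only a 1.1-fold lower number from compound 1 to compound 2 (0.05 log units; within the scatter) is at hand and it does not bear on this change; no step beyond the scatter is expected in this assay. Compound 3 is therefore estimated at 900 nM, with a range of 300 nM to 2700 nM, meaning a step of a 1.1-fold lower number from compound 1 to compound 3 (0.03 log units; within the scatter).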

Compound 3, half-maximal inhibitory concentration: 2660 nM
Estimate against measurement, compound 3: 3.0-fold (0.47 log units) below; low and high end bracket the measured number.
By their numbers in this assay, from the lowest: compounds 2 and 1 (each within the scatter of the next); then compound 3.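

In this assay, chloro in place of hydrogen on this aromatic carbon, between two ring nitrogen atoms, gives a 2.8-fold higher number from compound 1 to compound 3 (0.44 log units; beyond the scatter). Among these compounds, this shows that the position responds to substitution, and that here the change weakens inhibition, whereas the only earlier step, a change of configuration, stayed within the scatter. What is known about these compounds does not account for this step.

As far as these compounds go, whether fluoro, methyl or an amine at this position would raise the number as far remains open. So does whether chloro would act in the same way on compound 2.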